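This account rests on a few compounds, and the source may have more. Where it says the series, first, only, none or still open, it means among the compounds named here.

Of the compounds shown here, three have been measured in an in vitro ADME assay on microsomes (Homo sapiens) for metabolic stability; a lower number here means that the compound disappears faster, a higher number that the compound lasts longer. Compound 1 `CCc1nc(NC(CC)CC)c(OC)nc1-c1ccc(Cl)cc1Cl` gives 0.583 h, compound 2 `CCc1nc(-c2ccc(OC)cc2C(F)(F)F)c(CC)nc1NC(CC)CC` gives 0.2 h, and compound 3 `CCc1nc(-c2ccc(C)cc2OC)c(CC)nc1NC(CC)CC` gives 0.183 h. Compound 3 therefore stands level with compound 2 within the usual scatter, while compound 1 lies higher by a margin beyond the scatter.

Compound 4 `CCc1nc(-c2ccc(C(F)(F)F)cc2OC)c(CC)nc1NC(CC)CC` differs from compound 3 in one place: trifluoromethyl in place of methyl on an aromatic carbon, meta to a methoxy group and para to a large group (trifluoromethyl in place of methyl on an aromatic carbon). Within the data shown here, no pair of measured compounds shows a single change of this kind, so the data give no direct guide to its size. Among the measured compounds shown here, the nearest evidence is compound 2, the only measured compound with a trifluoromethyl group, and with 0.2 h compound 2 offers no support for a large step. A small rise is expected, amounting to an estimated 1.3-fold higher number from compound 3 to compound 4 (0.12 log units; within the scatter), which would not go beyond the scatter. In this assay the estimate for compound 4 is 0.24 h, with an expected range from 0.12 h to 0.48 h.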

Compound 4, half-life: 0.183 h
Estimate against measurement, compound 4: 1.3-fold (0.12 log units) above, and the stated range covers the measured number.
By their numbers in this assay, from the lowest: compounds 3, 4 and 2 (each within the scatter of the next); then compound 1.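

In this assay the one step shown at this position reads no change at the digits printed from compound 3 to compound 4 (within the scatter) for trifluoromethyl in place of methyl on an aromatic carbon, meta to a methoxy group and para to a large group. At this place, therefore, going from 1 heavy atom to 4 heavy atoms, 3 of them fluorine, brings no step beyond the scatter when the rest of the molecule stays the same. No measurement on hand gives a reason for this outcome.

The compounds shown leave open whether another group at this place, such as a nitrile, an amine or a carboxylic acid, would shift the half-life beyond the scatter. They also leave open whether the same exchange would read alike with chlorine in place of the methoxy group.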